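Replacing the 2-Chlorophenyl Acyl Group with Ethyl

The source may hold more compounds than are shown below. What is called first, only, known or untested is meant among the compounds shown, and "the series" means these compounds.

In a functional assay on NCI-H23 cells (Homo sapiens) for cytotoxicity, read by sulforhodamine B assay, with a stated time of 72 h (a lower number here means a stronger inhibitor of growth, a higher number a weaker inhibitor of growth), compound 2 `O=C(Nc1ccccc1C(F)(F)F)C1CCc2ccccc2N1C(=O)c1ccccc1Cl` gives 2150 nM, the lowest of the two numbers recorded. Compound 3 `O=C(Nc1ccccc1O)C1CCc2ccccc2N1C(=O)c1ccccc1Cl` gives 46900 nM, and the step of a 22-fold higher number from compound 2 to compound 3 (1.34 log units; beyond the scatter) shows how far a single change on an aromatic carbon can move this assay. Compound 1 `CC(=O)N1c2ccccc2CCC1C(=O)Nc1cc(C(F)(F)F)cc(C(F)(F)F)c1` gives > 70000 nM, which is the limit of > 70000 nM in this assay, at which 1 of the 3 values shown sits, rather than a number. Compound 4 `CCC(=O)N1c2ccccc2CCC1C(=O)Nc1ccccc1C(F)(F)F` differs from compound 2 by ethyl in place of 2-chlorophenyl on a carbonyl carbon. Going by the values given here, no measured step covers this change directly; the nearest comparison is compound 1, which also lacks the 2-chlorophenyl and sits at the limit. Compound 4 is therefore expected to give a higher number, with a 7.0-fold higher number from compound 2 to compound 4 (0.84 log units; beyond the scatter) estimated, so that compound 4 is expected at 15000 nM within a range of 4000 nM to 60000 nM.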

Compound 4, concentration for 50% growth inhibition: > 80000 nM
Compound 4: only a limit was reported; the forecaster's own chance of this, stated with the estimate: 25%; at least 5.3-fold (0.72 log units) between middle value and limit.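

In this assay, ethyl in place of 2-chlorophenyl on a carbonyl carbon gives an at least 37-fold higher number from compound 2 to compound 4 (1.57 log units; beyond the scatter) and so shows that the growth inhibition of compound 2 depends on this acyl group, not only on the trifluoromethyl group whose replacement was seen earlier. The value of compound 4 is a limit, not a number: the limit of > 80000 nM in this assay, at which 1 of the 4 values shown sits.

The compounds shown leave open whether the ring or the chlorine matters here, since a plain phenyl on this carbonyl carbon does not appear among them. Going by these compounds, whether a cyclohexyl or a longer chain would keep any of the growth inhibition also remains open.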